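Basic ring substituent on the propoxy chain of the core

The source may hold more compounds than are shown below. What is called first, only, known or untested is meant among the compounds shown, and "the series" means these compounds.

Working notes on the series. In an assay on cerebellum for displacement of a labelled ligand from histamine H1 receptor (Cavia porcellus), read by scintillation counting, with a stated time of 60 min (on this read-out higher numbers stand for weaker inhibition and lower numbers for stronger inhibition), compound 1 `CN1CCc2ccc(OCCCN3CCCCC3)cc2C1=O` gives 23 nM, compound 2 `CC1CCN(CCCOc2ccc3c(c2)C(=O)N(C)CC3)CC1` gives 32 nM and compound 3 `CCN(CC)CCCOc1ccc2c(c1)C(=O)N(C)CC2` gives 542 nM. Compound 2 stands second highest of the three numbers: nearest is compound 1, the gap being a 1.4-fold higher number from compound 1 to compound 2 (0.14 log units; within the scatter); furthest is compound 3, the gap being a 17-fold higher number from compound 2 to compound 3 (1.23 log units; beyond the scatter). The step of a 24-fold higher number from compound 1 to compound 3 (1.37 log units; beyond the scatter) shows the same large loss when the ring is opened.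

Compound 4 `CN1CCc2ccc(OCCCN3CCC(=O)CC3)cc2C1=O` differs from compound 2 as follows: 4-oxopiperidin-1-yl in place of 4-methylpiperidin-1-yl on a saturated chain carbon, three bonds along the chain from an oxygen on an aromatic ring. The ring is kept, so the two large steps to compound 3 do not apply directly. For the measured compounds named here, the only step touching the ring carbon in question, a 1.4-fold higher number from compound 1 to compound 2 (0.14 log units; within the scatter), was within the scatter, but no measured step covers an oxo group on that carbon, so the outcome is uncertain. A modest weakening is expected, a 2.0-fold higher number from compound 2 to compound 4 (0.31 log units; beyond the scatter), with a wide range. Compound 4 is therefore estimated at 65 nM in this assay, between 20 nM and 220 nM.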

Compound 4, inhibition constant: 176 nM
The estimate for compound 4 lay 2.7-fold (0.43 log units) below the measured number, within the range that was stated.
By their numbers in this assay, from the lowest: compounds 1 and 2 (each within the scatter of the next); then compound 4; then compound 3.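

In this assay, the ring carbon that tolerated a methyl group, with a 1.4-fold higher number from compound 1 to compound 2 (0.14 log units; within the scatter), does not accept every change, since the oxo group on that carbon gives a 5.5-fold higher number from compound 2 to compound 4 (0.74 log units; beyond the scatter) and, against the unsubstituted ring, a 7.7-fold higher number from compound 1 to compound 4 (0.88 log units; beyond the scatter). The 4-oxopiperidin-1-yl group still does better than the open diethylamino group, with a 3.1-fold lower number from compound 3 to compound 4 (0.49 log units; beyond the scatter), so this change costs less than the loss seen on opening the ring. Nothing available bears on why the oxo group weakens the number.

Open, on these data alone, is whether the loss belongs to the carbonyl alone or to any oxygen on that ring carbon. A hydroxyl group on that carbon, or morpholin-4-yl in place of the whole ring, would help to separate these two readings.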